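The source may report more compounds than this note shows. Statements on the series, on what has been measured and on what is new or still open speak of the compounds shown alone.

Measured compounds:
compound 1, `N#Cc1cc2c(nc1N1CCC(C(=O)NS(=O)(=O)C3(c4ccccc4)CC3)CC1)COC2=O`: 4100 nM
compound 2, `N#Cc1cc2c(nc1N1CCC(C(=O)NS(=O)(=O)Cc3ccccc3)C1)COC2=O`: > 300000 nM
compound 3, `N#Cc1cc2c(nc1N1CCC(C(=O)NS(=O)(=O)Cc3ccccc3)CC1)CCC(Cl)C2=O`: > 300000 nM

All three were tested in a functional assay (Platelet, plasma) for inhibition, with Homo sapiens as the target; on this read-out lower numbers stand for stronger inhibition and higher numbers for weaker inhibition. Going by the values given here, compound 1 gives 4100 nM, the only real number among the three. For compound 2 the result > 300000 nM is a limit of the assay, not a number. For compound 3 the result > 300000 nM is likewise a limit. So compound 1 stands alone with a measured value, while the other two sit at the limit of > 300000 nM in this assay, at which 2 of the 3 values shown sit.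

Compound 4, `N#Cc1cc2c(nc1N1CCC(C(=O)NS(=O)(=O)Cc3ccc(C(F)(F)F)cc3)CC1)COC2=O`, has not yet been tested in this assay. It differs from compound 1 in one place: 4-(trifluoromethyl)benzyl in place of 1-phenylcyclopropyl on a sulfonyl sulfur. Among the compounds with values here, no pair of measured compounds isolates this exchange. Compounds 2 and 3 also carry a benzyl group on the sulfonyl sulfur, but each differs from compound 1 in a further place as well, so their values speak only loosely to compound 4. Still, compound 2 at its limit > 300000 nM gives some warning. Compound 3 at its limit > 300000 nM gives the same warning.

The estimated step of a 6.1-fold higher number from compound 1 to compound 4 (0.79 log units; beyond the scatter) is therefore expected to go toward weaker inhibition, clearly beyond the scatter. Compound 4 is expected to give about 25000 nM, within a range of 5000 nM to 200000 nM.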

Compound 4, half-maximal inhibitory concentration: 15900 nM
For compound 4 the middle estimate is 1.6-fold (0.20 log units) above the measured one; the measured number falls inside the stated range.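

In this assay, going by these compounds alone, putting 4-(trifluoromethyl)benzyl in place of 1-phenylcyclopropyl on a sulfonyl sulfur gives a 3.9-fold higher number from compound 1 to compound 4 (0.59 log units; beyond the scatter), which means weaker inhibition and is the first step here that can be read as a change in one place. The group on the sulfonyl sulfur therefore affects the read-out, yet this exchange costs only a modest amount, and compound 4 still gives a real number rather than a limit. Compounds 2 and 3 each differ from compound 4 in more than one place, so they cannot be compared directly with it, and their results remain limits rather than numbers: the limit of > 300000 nM in this assay, at which 2 of the 4 values shown sit.

This single step swaps the whole group at once, so it cannot separate the loss of the three-membered ring from the arrival of the trifluoromethyl group. It also leaves open how the core of compound 1 would respond to other groups at this place, such as a carboxylic acid, an amine or a longer chain like 2-phenylethyl.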